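This account rests on a few compounds, and the source may have more. Where it says the series, first, only, none or still open, it means among the compounds named here.

In an ADME assay on Vero cells (Chlorocebus sabaeus) for cytotoxicity, with a stated time of 72 h (a higher number here means a weaker inhibitor, a lower number a stronger inhibitor), compound 3 `CCOC(=O)c1cc(/C=C/c2ccsc2)on1` gives > 128000 nM, which is a limit and not a number. Compound 1 `CCOC(=O)c1cc(/C=C/c2ccncc2)on1` gives > 128000 nM, also a limit. Compound 2 `CCOC(=O)c1cc(/C=C/c2ccccc2)on1` has the entry "not determined" (no result reported). Compound 3 therefore stands at the limit of > 128000 nM in this assay, at which 2 of the 3 values shown sit. Within the data shown here, the only measured step is a step that the two limits leave unreadable from compound 1 to compound 3, so it offers no size to carry forward. Compound 4 `CCOC(=O)c1cc(/C=C/c2ccco2)on1` has furan-2-yl in place of thiophen-3-yl on a double-bonded chain carbon bound to a double-bonded chain carbon. No step beyond the scatter is expected in this assay, and no direction can be assigned. The expected step is an at least 1.0-fold lower number from compound 3 to compound 4 (0.02 log units; that floor lies within the scatter). The estimate for compound 4 is 120000 nM, with an expected range of 45000 nM to 128000 nM.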

Compound 4, half-maximal inhibitory concentration: > 128000 nM
Compound 4 gave a limit, no number; the forecaster's own chance of this, stated with the estimate: 70%; middle value at least 1.0-fold (0.02 log units) from the limit.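

Compound 1, compound 3 and compound 4 all give only a limit in this assay, so no step among them can be read: the limit of > 128000 nM in this assay, at which 3 of the 4 values shown sit.

The compounds shown leave open whether pyridin-4-yl, thiophen-3-yl and furan-2-yl differ at all in this assay.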